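A Methyl-to-Chloro Swap, Measured Once, Expected Again

A few compounds are considered here, and "the series" means these few. Any claim that something is new, unique, unknown or untested is made for them only; others in the source may bear on it.

Compound 1, `Cc1ccc(NC(=S)NC(=O)c2ccc(OCc3ccc(Cl)cc3Cl)cc2)cc1-c1nc2ccccc2[nH]1`, gives 5300 nM in a functional assay on MNK45 cells (Homo sapiens) for inhibition, read by MTT assay, with a stated time of 48 h; a lower number here means a stronger inhibitor, a higher number a weaker inhibitor.
Compound 2, `O=C(NC(=S)Nc1ccc(Cl)c(-c2nc3ccccc3[nH]2)c1)c1ccc(OCc2ccc(Cl)cc2Cl)cc1`, gives 3750 nM in this assay.
Compound 3, `Cc1ccc(NC(=O)NC(=O)c2ccc(OCc3ccccc3F)cc2)cc1-c1nc2ccccc2[nH]1`, gives 1830 nM in this assay.

Compound 1 and compound 2 share one core and differ in a single spot: chloro in place of methyl on an aromatic carbon. That change made a 1.4-fold lower number from compound 1 to compound 2 (0.15 log units; within the scatter), so on this core it hardly moved the number. Compound 3 stands on a different core; how the two cores differ is not broken down here, and compound 3 simply has the lowest of the three numbers.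

Compound 4, `O=C(NC(=O)c1ccc(OCc2ccccc2F)cc1)Nc1ccc(Cl)c(-c2nc3ccccc3[nH]2)c1`, is not yet measured. It relates to compound 3 the way compound 2 relates to compound 1: chloro in place of methyl on an aromatic carbon. The surroundings of the change are described in the same words in both pairs, so it is the same change on another core.

The expectation is a step of a 1.4-fold lower number from compound 3 to compound 4 (0.15 log units; within the scatter) in this assay, because the same change gave a 1.4-fold lower number from compound 1 to compound 2 (0.15 log units; within the scatter) and nothing here suggests the new core would answer differently. Compound 4 is therefore estimated at 1300 nM, most likely between 600 nM and 3000 nM.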

Compound 4, half-maximal inhibitory concentration: 870 nM
Compound 4: the middle estimate sits 1.5-fold (0.17 log units) above what was measured; the measured number falls inside the stated range.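

Putting chloro in place of methyl on compound 3 gave a 2.1-fold lower number from compound 3 to compound 4 (0.32 log units; beyond the scatter) in this assay, a modest step on this core. Set beside the step on the other core, it shows no difference larger than repeat measurements could produce, so in these two pairs the change carried over from one core to the other with much the same size: the same change on two cores in this assay, a 1.4-fold lower number (0.15 log units; within the scatter) from compound 1 to compound 2 and a 2.1-fold lower number (0.32 log units; beyond the scatter) from compound 3 to compound 4, 1.5-fold (0.17 log units) apart, within the scatter of two such steps. Within the data shown here, this rests on only two pairs in a single cell assay, so it does not show that the step would keep this size on other cores, and it does not explain why the number moves.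

The compounds shown leave open what other groups on the same ring carbon, such as a methoxy group, a nitrile or an amine, would do to the number in this assay. They also leave open which of the several differences between the two cores accounts for the gap between compound 1 and compound 3.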